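Thiophen-2-yl in place of 4-fluorophenyl

The source may report more compounds than this note shows. Statements on the series, on what has been measured and on what is new or still open speak of the compounds shown alone.

In a functional assay on HCT-116 cells (Homo sapiens) for inhibition, read by MTT assay, with a stated time of 72 h (on this read-out higher numbers stand for weaker inhibition and lower numbers for stronger inhibition), compound 1 (`Nc1ccccc1NC(=O)c1ccc(CNCc2nc(-c3ccc(C(F)(F)F)cc3)no2)cc1`) gives 19700 nM, and compound 2 (`Nc1ccccc1NC(=O)c1ccc(CNCc2nc(-c3ccc(F)cc3)no2)cc1`) gives 3510 nM, the lower of the two numbers. Compound 3 (`Nc1ccccc1NC(=O)c1ccc(CNCc2nc(-c3cccs3)no2)cc1`) keeps the core of compound 2 and differs at one place: thiophen-2-yl in place of 4-fluorophenyl on an aromatic carbon. Thiophen-2-yl stands in place of 4-fluorophenyl on an aromatic carbon. Among the measured compounds shown here, only one measured step bears on this change, and only loosely: a 5.6-fold lower number from compound 1 to compound 2 (0.75 log units; beyond the scatter), where fluoro replaced trifluoromethyl on an aromatic carbon. That modest step did not exchange a whole ring, so it gives no firm direction. Resting on a 5.6-fold lower number from compound 1 to compound 2 (0.75 log units; beyond the scatter), a smaller step, possibly within the scatter and leaning slightly towards a lower number, is expected in this assay. The estimated change is a 1.3-fold lower number from compound 2 to compound 3 (0.10 log units; within the scatter). For compound 3 the expected value is 2800 nM, with an estimated range of 900 nM to 9000 nM.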

Compound 3, half-maximal inhibitory concentration: 27200 nM
Beside the measured number, compound 3's estimate is 9.7-fold (0.99 log units) below it; measured number outside the range, above it.
By their numbers in this assay, from the lowest: compound 2; then compounds 1 and 3 (each within the scatter of the next).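

In this assay this place on the shared core proves sensitive to the ring it carries: the exchange of 4-fluorophenyl for thiophen-2-yl brings a 7.7-fold higher number from compound 2 to compound 3 (0.89 log units; beyond the scatter) and leaves compound 2 with the lowest number of the three. Thiophen-2-yl and 4-(trifluoromethyl)phenyl do not separate, with a 1.4-fold higher number from compound 1 to compound 3 (0.14 log units; within the scatter) as the step between them. Among these three groups, the lower number therefore belongs to 4-fluorophenyl alone, and an aromatic ring at this place does not by itself secure it; no available evidence accounts for this order.

The compounds shown leave open whether a plain phenyl, a 4-chlorophenyl or a 4-aminophenyl group would match 4-fluorophenyl. They also do not tell whether the outcome with thiophen-2-yl extends to other five-membered aromatic rings, such as furan-2-yl.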